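A few compounds are considered here, and "the series" means these few. Any claim that something is new, unique, unknown or untested is made for them only; others in the source may bear on it.

Going by the values given here, compound 1 `Cc1nc2c3ccccc3ccc2c2nc3c(ccc4ccccc43)c(-c3cc([N+](=O)[O-])ccc3N)c12` gives 43.3 ug/mL in a functional assay, read by spectrophotometry, with a stated time of 15 min (a lower number here means a stronger inhibitor, a higher number a weaker inhibitor), the lowest of the three numbers so far, though the gap to compound 3 is within the scatter. Compound 3 `Cc1nc2c3ccccc3ccc2c2nc3c(ccc4ccccc43)c(-c3nccnc3N)c12` gives 47.8 ug/mL in this assay, and compound 2 `Cc1nc2c3ccccc3ccc2c2nc3c(ccc4ccccc43)c(C)c12` gives 89.6 ug/mL. Compound 4 `Cc1nc2c3ccccc3ccc2c2nc3c(ccc4ccccc43)c(-c3cccc4ccccc34)c12` is not yet measured; it differs from compound 1 by naphthalen-1-yl in place of 2-amino-5-nitrophenyl on an aromatic carbon. Two steps at the same aromatic carbon bear on this: a 2.1-fold higher number from compound 1 to compound 2 (0.32 log units; beyond the scatter), and a 1.1-fold higher number from compound 1 to compound 3 (0.04 log units; within the scatter). An aromatic group replacing another aromatic group resembles the second step more than the first, so for compound 4 in this assay no step beyond the scatter is expected, a 1.2-fold higher number from compound 1 to compound 4 (0.06 log units; within the scatter). Compound 4 is therefore estimated at 50 ug/mL, within a range of 25 ug/mL to 100 ug/mL.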

Compound 4, half-maximal inhibitory concentration: 64.3 ug/mL
For compound 4 the middle estimate is 1.3-fold (0.11 log units) below the measured one; low and high end bracket the measured number.
By their numbers in this assay, from the lowest: compounds 1, 3, 4 and 2 (each within the scatter of the next, the first and the last beyond it).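

In this assay, naphthalen-1-yl, with 0 hydrogen-bond donors and 0 hydrogen-bond acceptors, gives a 1.5-fold higher number from compound 1 to compound 4 (0.17 log units; within the scatter) and a 1.3-fold higher number from compound 3 to compound 4 (0.13 log units; within the scatter), so at this aromatic carbon the amino-bearing aryl groups are not told apart from an all-carbon one. Against methyl it gives a 1.4-fold lower number from compound 2 to compound 4 (0.14 log units; within the scatter), which places compound 4 within the scatter of every other compound and leaves the step from compound 1 to compound 2 as the only one beyond it. No evidence on why these numbers stay so close is available.

On these data alone, whether a carboxylic acid, a saturated amine or a longer alkyl chain at this carbon would move the number beyond the scatter remains open.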